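An Azido Group Added to Compound 2

The compounds below may be only part of what the source reports. "The series", "measured", "known", "first", "only" and "open" are said of these compounds alone.

Compound 1, `[N-]=[N+]=Nc1cc(Cl)ncc1Cn1ccsc1=N`: 110 nM
Compound 2, `O=[N+]([O-])/C=C1\NC=CN1Cc1ccc(Cl)nc1`: 60 nM

In an assay on M10 cells (Gallus gallus) for binding affinity to Neuronal acetylcholine receptor; alpha4/beta2 (Homo sapiens) (on this read-out higher numbers stand for weaker inhibition and lower numbers for stronger inhibition), compound 1 gives 110 nM and compound 2 gives 60 nM. Compound 2 has the lower of the two numbers, but compound 1 lies within the scatter of it, so no order between them can be claimed. Compound 3, `[N-]=[N+]=Nc1cc(CN2C=CN/C2=C\[N+](=O)[O-])cnc1Cl`, differs from compound 2 by azido in place of hydrogen on an aromatic carbon. For the measured compounds named here, compound 1 also carries an azido group but differs from compound 2 elsewhere too, so no measured step isolates this change. The expected step is a 1.3-fold higher number from compound 2 to compound 3 (0.12 log units; within the scatter), none beyond the scatter. Compound 3 is estimated at 80 nM, ranging from 30 nM to 250 nM.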

Compound 3, inhibition constant: 40 nM
Beside the measured number, compound 3's estimate is 2.0-fold (0.30 log units) above it; the range from low to high includes it.
By their numbers in this assay, from the lowest: compounds 3, 2 and 1 (each within the scatter of the next, the first and the last beyond it).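

Replacing hydrogen with azido on this aromatic carbon, ortho to a chloro group, gives a 1.5-fold lower number from compound 2 to compound 3 (0.18 log units; within the scatter) in this assay. For the compounds shown here, this is the first step that isolates the change, and it shows that this added group of three nitrogen atoms leaves the number within the scatter at this position. No evidence shown offers a reason for this result. Still open, going by these compounds, is how an amine, a methoxy group or a longer chain on the same carbon would compare with azido and hydrogen in this read-out.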